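Keto amides and a keto acid: the benzylamino change

The source may report more compounds than this note shows. Statements on the series, on what has been measured and on what is new or still open speak of the compounds shown alone.

Measured in a functional assay for inhibition, with Rattus norvegicus as the target, at pH 7.35; a lower number here means a stronger inhibitor, a higher number a weaker inhibitor:
- compound 1 `CCCCNC(=O)C(=O)C(CC)NC(=O)C(CC(C)C)NC(=O)OCc1ccccc1`: 35000 nM
- compound 2 `CCC(NC(=O)C(CC(C)C)NC(=O)OCc1ccccc1)C(=O)C(=O)NCc1ccccc1`: 50000 nM

Within the scatter of compound 1, compound 2 stands at 50000 nM. Compound 3 `CCC(NC(=O)C(CC(C)C)NC(=O)OCc1ccccc1)C(=O)C(=O)O` has not been measured. It differs from compound 2 by hydroxy in place of benzylamino on a carbonyl carbon. Going by the values given here, the one measured step, a 1.4-fold higher number from compound 1 to compound 2 (0.15 log units; within the scatter), lies within the scatter. Among the compounds with values here, that step keeps the amide, and no measured step removes it, so the guide is weak. The estimate is a 2.0-fold higher number from compound 2 to compound 3 (0.30 log units; within the scatter), an expected move to a higher number in this assay, with wide uncertainty. For compound 3 the expected value is 100000 nM, with an estimated range of 20000 nM to 500000 nM.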

Compound 3, half-maximal inhibitory concentration: 100000 nM
Compound 3: middle estimate and measured number agree at the digits printed; the range from low to high includes it.
By their numbers in this assay, from the lowest: compounds 1, 2 and 3 (each within the scatter of the next, the first and the last beyond it).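

In this assay, going by these compounds alone, hydroxy in place of benzylamino on a carbonyl carbon gives a 2.0-fold higher number from compound 2 to compound 3 (0.30 log units; within the scatter) and so stays within the scatter, the first reading of a change that removes the amide. Hydroxy in place of butylamino at that place gives a 2.9-fold higher number from compound 1 to compound 3 (0.46 log units; beyond the scatter) and is a modest step beyond the scatter, so the reading depends on which amide is the reference. Nothing measured here speaks to a cause for either step.

Open, on these data alone, is how a methyl ester or a longer chain in place of hydroxy on this carbonyl carbon would read against compound 2 and compound 3.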